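Swapping Methoxy for Bromo on the Pendant Phenyl Ring

This account rests on a few compounds, and the source may have more. Where it says the series, first, only, none or still open, it means among the compounds named here.

Compound 1 `CNC(=O)c1cc(Oc2ccc(C3=NNC(c4cccc(Br)c4)C3)cc2)ccn1` gives 3540 nM in a functional assay on PC-3 cells (Homo sapiens) for cytotoxicity, read by MTT assay, with a stated time of 72 h; on this read-out higher numbers stand for weaker inhibition and lower numbers for stronger inhibition.
Compound 2 `CNC(=O)c1cc(Oc2ccc(C3=NNC(c4ccc([N+](=O)[O-])cc4)C3)cc2)ccn1` gives > 50000 nM in this assay, a limit rather than a number.
Compound 3 `CNC(=O)c1cc(Oc2ccc(C3=NNC(c4ccc(OC)cc4)C3)cc2)ccn1` gives 7740 nM in this assay.

All three share one core and differ only in the aryl group attached to a saturated ring carbon. Of the two plain numbers, compound 3 carries the higher one; its nearest neighbour is compound 1, with a 2.2-fold higher number from compound 1 to compound 3 (0.34 log units; beyond the scatter). Compound 2 sits at a limit of this assay (the limit of > 50000 nM in this assay, at which 1 of the 3 values shown sits). Between compounds 2 and 3 the change is an at least 6.4-fold lower number from compound 2 to compound 3 (0.81 log units; beyond the scatter).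

Compound 4 `CNC(=O)c1cc(Oc2ccc(C3=NNC(c4ccc(Br)cc4)C3)cc2)ccn1` has not yet been measured. It differs from compound 3 as follows: bromo in place of methoxy on an aromatic carbon. Going by the values given here, the measured step that bears most on this is the one from compound 1 to compound 3, a modest rise, as a 2.2-fold higher number from compound 1 to compound 3 (0.34 log units; beyond the scatter) shows. That step too exchanges a bromo-bearing phenyl for 4-methoxyphenyl. The nitro step stands far apart. Reversing the methoxy for bromo is therefore expected to give a modest fall, about a 1.9-fold lower number from compound 3 to compound 4 (0.29 log units; within the scatter). Compound 4 is thus estimated at 4000 nM, within a range from 1500 nM to 10000 nM.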

Compound 4, half-maximal inhibitory concentration: > 50000 nM
Compound 4 ended at the assay's limit; the forecaster's own chance of this, stated with the estimate: 3%; at least 12-fold (1.09 log units) between middle value and limit.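

Putting bromo in place of methoxy on this aromatic carbon weakens the compound in this assay, with an at least 6.4-fold higher number from compound 3 to compound 4 (0.81 log units; beyond the scatter). The place of the bromine on the phenyl ring also matters: going from 3-bromophenyl to 4-bromophenyl gives an at least 14-fold higher number from compound 1 to compound 4 (1.14 log units; beyond the scatter), so one bromo-bearing phenyl cannot stand in for the other. Compound 4 gives a limit rather than a number, as does compound 2, so the step between them cannot be read: the limit of > 50000 nM in this assay, at which 2 of the 4 values shown sit.

Among the three groups compared at this spot, only methoxy gives a plain number, so it stays open whether an amine or a hydroxy group there would also give one. From the compounds shown here alone, how the true values of compound 2 and compound 4 compare also stays open.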